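Taking the nitrile off compound 3

A few compounds are considered here, and "the series" means these few. Any claim that something is new, unique, unknown or untested is made for them only; others in the source may bear on it.

Of the compounds shown here, three sharing one core have been measured in an ADME assay on liver for metabolic stability, with Liver microsome (Homo sapiens) as the target, using microsomes; on this read-out lower numbers stand for slow clearance and higher numbers for fast clearance. In this assay, compound 1 (`O=C(Nc1cc(-c2ccccn2)n[nH]1)N1CCC(c2cccc(F)c2)CC1`) gives 25.3 mL.min-1.g-1, compound 2 (`N#Cc1ccc(C2CCN(C(=O)Nc3cc(-c4ccccn4)n[nH]3)CC2)cc1`) gives 25.3 mL.min-1.g-1 and compound 3 (`N#Cc1ccc(OC2CCN(C(=O)Nc3cc(-c4ccccn4)n[nH]3)CC2)cc1`) gives 14.7 mL.min-1.g-1. Compound 3 therefore stands within the scatter of both others. The two steps that reach it read a 1.7-fold lower number from compound 1 to compound 3 (0.24 log units; within the scatter) and a 1.7-fold lower number from compound 2 to compound 3 (0.24 log units; within the scatter).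

The next compound, compound 4 (`O=C(Nc1cc(-c2ccccn2)n[nH]1)N1CCC(Oc2ccccc2)CC1`), has hydrogen in place of cyano on an aromatic carbon, para to a large group, so that 4-cyanophenoxy becomes phenoxy: hydrogen in place of cyano on an aromatic carbon. Among the measured compounds shown here, no measured step removes the nitrile alone. The closest evidence is the exchange of 3-fluorophenyl for 4-cyanophenyl, which reads no change at the digits printed from compound 1 to compound 2 (within the scatter). The exchange of 4-cyanophenyl for 4-cyanophenoxy, already given above, also stays within the scatter. None of the three steps therefore points to a large move in this assay, and no change beyond the scatter is expected. A slight lean upward is allowed for, since compound 1, which carries no nitrile, gives 25.3 mL.min-1.g-1. The expected step is a 1.3-fold higher number from compound 3 to compound 4 (0.11 log units; within the scatter). Compound 4 is estimated at 19 mL.min-1.g-1, with an expected range of 11 mL.min-1.g-1 to 34 mL.min-1.g-1.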

Compound 4, intrinsic clearance in microsomes: 27.3 mL.min-1.g-1
Estimate against measurement, compound 4: 1.4-fold (0.16 log units) below, within the range that was stated.
By their numbers in this assay, from the lowest: compounds 3, 1, 2 and 4 (each within the scatter of the next).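

In this assay, among the compounds shown here, the step that takes away the nitrile alone, hydrogen in place of cyano on an aromatic carbon para to a large group, reads a 1.9-fold higher number from compound 3 to compound 4 (0.27 log units; within the scatter); this is the first direct reading of that change, and it stays within the scatter. For the compounds shown here, the unsubstituted phenoxy group also stays within the scatter of the two groups carried by the earlier compounds, with a 1.1-fold higher number from compound 2 to compound 4 (0.03 log units; within the scatter) and a 1.1-fold higher number from compound 1 to compound 4 (0.03 log units; within the scatter), so none of the single exchanges printed for this substituent on the saturated ring carbon separates two compounds beyond the scatter. No measured evidence bears on these readings.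

The compounds shown leave open whether a different group at the same aromatic carbon, such as an amine, a carboxylic acid or a methoxy group, would give a step beyond the scatter. They also leave open whether a longer chain in place of the phenoxy oxygen link, or any change elsewhere on the shared core, would give a number clearly apart from the four readings seen so far.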